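Working notes: a third methoxy entering after compound 3

The source may hold more compounds than are shown below. What is called first, only, known or untested is meant among the compounds shown, and "the series" means these compounds.

Among the compounds with values here, the three measured members share one core and differ only in the aryl group on the amine nitrogen. Compound 1 `COc1ccc(N/C(CCNC2=CC(=O)c3ccccc3C2=O)=N\S(=O)(=O)c2ccc(C)cc2)cc1` carries a 4-methoxyphenyl there, and in a functional assay on MCF7 cells (Homo sapiens) for cytotoxicity, read by MTT assay, with a stated time of 48 h (on this read-out lower numbers stand for stronger inhibition and higher numbers for weaker inhibition), compound 1 gives 6030 nM. Compound 2 `Cc1ccc(S(=O)(=O)/N=C(/CCNC2=CC(=O)c3ccccc3C2=O)Nc2ccc(F)cc2)cc1` carries a 4-fluorophenyl; in this assay compound 2 gives 4260 nM, and the step is a 1.4-fold lower number from compound 1 to compound 2 (0.15 log units; within the scatter). Compound 3 `COc1ccc(N/C(CCNC2=CC(=O)c3ccccc3C2=O)=N\S(=O)(=O)c2ccc(C)cc2)cc1OC` carries a 3,4-dimethoxyphenyl; in this assay compound 3 gives 12300 nM, the highest number of the three, reached by a 2.0-fold higher number from compound 1 to compound 3 (0.31 log units; beyond the scatter) and by a 2.9-fold higher number from compound 2 to compound 3 (0.46 log units; beyond the scatter).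

Compound 4 `COc1cc(N/C(CCNC2=CC(=O)c3ccccc3C2=O)=N\S(=O)(=O)c2ccc(C)cc2)cc(OC)c1OC` is not yet measured. Relative to compound 3 the change is methoxy in place of hydrogen on an aromatic carbon.

Within the data shown here, the step that bears most directly on this is the one from compound 1 to compound 3, where a methoxy also entered on this ring and the number rose modestly; the step from compound 2 to compound 3 went the same way and was a little larger. The run is short, so the reading stays loose, but a further modest rise in the number is expected for compound 4, a 1.6-fold higher number from compound 3 to compound 4 (0.21 log units; within the scatter). The estimate for compound 4 in this assay is 20000 nM, with an expected range from 9000 nM to 45000 nM.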

Compound 4, half-maximal inhibitory concentration: 3050 nM
Estimate against measurement, compound 4: 6.6-fold (0.82 log units) above; the whole stated range lies above it.
By their numbers in this assay, from the lowest: compounds 4, 2 and 1 (each within the scatter of the next); then compound 3.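

The 3,4,5-trimethoxyphenyl group shows that a methoxy in place of hydrogen on this ring has no fixed direction: a 2.0-fold higher number from compound 1 to compound 3 (0.31 log units; beyond the scatter), whereas the methoxy entering ortho to a methoxy group and meta to a large group gives a 4.0-fold lower number from compound 3 to compound 4 (0.61 log units; beyond the scatter), so the number does not move one way across compounds 1, 3 and 4. Within the data shown here, the other two steps, a 1.4-fold lower number from compound 2 to compound 4 (0.15 log units; within the scatter) and a 2.0-fold lower number from compound 1 to compound 4 (0.30 log units; within the scatter), both lie within the scatter, which leaves compound 3 as the only member of the four that stands apart, with the highest number in this assay. Nothing available here accounts for the reversal between the two methoxy steps.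

Going by these compounds, whether the step belongs to methoxy specifically or to any group at this aromatic carbon remains open, and a hydroxy group, an ethoxy group or an amine there would begin to separate the two readings. Also open, on these data alone, is whether the high number of the 3,4-dimethoxyphenyl member, and its return with the third methoxy, holds outside this one cell read-out.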